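Fluoro in place of methyl: from compound 2 to compound 3

The compounds below may be only part of what the source reports. "The series", "measured", "known", "first", "only" and "open" are said of these compounds alone.

Measured so far:
Compound 1 `Cc1ccccc1-n1cc(-c2ccccc2NS(=O)(=O)c2c[nH]c(=O)[nH]c2=O)nn1`: 13900 nM
Compound 2 `Cc1cccc(-n2cc(-c3ccc(NS(=O)(=O)c4c[nH]c(=O)[nH]c4=O)cc3)nn2)c1`: > 20000 nM

Two compounds have been run in a functional assay on HepG2 cells (Homo sapiens) for antiproliferative activity, read by MTT assay, with a stated time of 24 h (on this read-out lower numbers stand for stronger inhibition and higher numbers for weaker inhibition), so far. Compound 1 gives 13900 nM in this assay. For compound 2 this assay returns only a limit, > 20000 nM, so compound 2 stands at the edge of the scale with no number of its own. No comparison between the two is drawn.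

Compound 3 `O=c1[nH]cc(S(=O)(=O)Nc2ccc(-c3cn(-c4cccc(F)c4)nn3)cc2)c(=O)[nH]1` is not yet measured. It differs from compound 2 by fluoro in place of methyl on an aromatic carbon, meta to a large group; cut one bond further out the change reads 3-methylphenyl to 3-fluorophenyl. For the measured compounds named here, no measured step between related compounds is available, so the step that the limit leaves unreadable from compound 2 to compound 3 is expected to be small, in no set direction, and not beyond the usual scatter. Compound 3 is therefore estimated at 25000 nM, with a range from 10000 nM to 60000 nM, and a limit rather than a number is expected to be the likelier report.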

Compound 3, half-maximal inhibitory concentration: > 20000 nM
Compound 3 ended at the assay's limit; the forecaster's own chance of this, stated with the estimate: 70%; the middle value does not contradict the limit.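

No step can be read from compound 2 to compound 3, because each returns only a limit and no number: the limit of > 20000 nM in this assay, at which 2 of the 3 values shown sit.

Left open is whether 3-methylphenyl and 3-fluorophenyl differ at all in this assay, as neither compound 2 nor compound 3 has a number of its own there.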